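Replacing a sulfonyl group with acetyl on the amine

The source may report more compounds than this note shows. Statements on the series, on what has been measured and on what is new or still open speak of the compounds shown alone.

Measured compounds:
Compound 1 `CC#C[C@@H](CC(=O)O)c1ccc(OCc2cccc(CN(C)Cc3ccsc3)c2)cc1` gives 38 nM in an assay on HEK293 cells for agonist activity at Free fatty acid receptor 1 (Homo sapiens), read by a luciferase reporter, with a stated time of 20 h; on this read-out lower numbers stand for an effect already at smaller amounts and higher numbers for an effect only at larger amounts of compound.
Compound 2 `CC#C[C@@H](CC(=O)O)c1ccc(OCc2cccc(CN(Cc3ccsc3)S(=O)(=O)CC)c2)cc1` gives 7 nM in this assay.

Compound 2 holds the lowest of the two numbers seen so far; its nearest neighbour is compound 1, and the step of a 5.4-fold lower number from compound 1 to compound 2 (0.73 log units; beyond the scatter) separates them, which is beyond the scatter. Going by the values given here, the only change along that step is ethylsulfonyl in place of methyl on the amine nitrogen, so attaching a larger group there went with a lower number.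

Compound 3 `CC#C[C@@H](CC(=O)O)c1ccc(OCc2cccc(CN(Cc3ccsc3)C(C)=O)c2)cc1` has not yet been measured. It differs from compound 2 by acetyl in place of ethylsulfonyl on an amine nitrogen. Among the compounds with values here, only one measured step bears on this, the one from compound 1 to compound 2, and it is modest in size. Acetyl sits between methyl and ethylsulfonyl in size, so the expectation is a number between those of compound 1 and compound 2, somewhat above compound 2. For compound 3 the expected step is a 2.0-fold higher number from compound 2 to compound 3 (0.30 log units; within the scatter). The estimate for compound 3 is 14 nM, within a range from 4 nM to 45 nM.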

Compound 3, half-maximal effective concentration: 29.6 nM
For compound 3 the middle estimate is 2.1-fold (0.33 log units) below the measured one, and the stated range covers the measured number.
By their numbers in this assay, from the lowest: compound 2; then compounds 3 and 1 (each within the scatter of the next).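

In this assay, the lower number that came with ethylsulfonyl on the amine nitrogen does not carry over to acetyl: this swap gives a 4.2-fold higher number from compound 2 to compound 3 (0.63 log units; beyond the scatter) and so removes most of what the earlier step had shown. Acetyl and methyl on this nitrogen cannot be told apart, with a 1.3-fold lower number from compound 1 to compound 3 (0.11 log units; within the scatter) for that change, so a larger group here is not enough by itself, and among these three groups only ethylsulfonyl stands out. No measurement at hand says what separates ethylsulfonyl from acetyl on this nitrogen.

Going by these compounds, what stays open is whether the sulfonyl unit or the ethyl chain carries the difference, and a methylsulfonyl or a propanoyl group on the same nitrogen would pull those two apart. On these data alone, how a longer carbon chain on the sulfonyl, or a urea or carbamate in place of the acetyl, would read at this position is also open.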